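Swapping the chlorohydroxyphenyl group for an ethoxyphenyl

The source may hold more compounds than are shown below. What is called first, only, known or untested is meant among the compounds shown, and "the series" means these compounds.

Of the compounds shown here, three sharing one core have been measured in an assay on HEK293 cells for displacement of a labelled ligand from Melanocortin receptor 4 (Homo sapiens); on this read-out lower numbers stand for stronger inhibition and higher numbers for weaker inhibition. Compound 1 `CC(C)C[C@H](N)c1cc(Cl)ccc1N1CCN(C(=O)C(C)Cc2ccc(Cl)cc2)CC1` gives 67 nM, compound 2 `CC(C)C[C@H](N)c1cc(C(F)(F)F)ccc1N1CCN(C(=O)C(C)Cc2ccc(Cl)cc2O)CC1` gives 36 nM, and compound 3 `COc1cc(Cl)ccc1C[C@@H](C)C(=O)N1CCN(c2ccc(C)cc2[C@@H](N)CC(C)C)CC1` gives 8.1 nM. Compound 2 thus stands second highest of the three; its nearest neighbour is compound 1, within the usual scatter, while compound 3 lies furthest away with a number that is lower beyond the scatter.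

Compound 4 `CCOc1cccc(CC(C)C(=O)N2CCN(c3ccc(C(F)(F)F)cc3[C@@H](N)CC(C)C)CC2)c1` is not yet measured. It differs from compound 2 in one place: 3-ethoxyphenyl in place of 4-chloro-2-hydroxyphenyl on a saturated chain carbon, two bonds along the chain from a carbonyl carbon. Among the compounds with values here, the hydroxyl that compound 2 carries and compound 1 lacks did not separate the two beyond the scatter, and no measured pair isolates the chlorine or the ethoxy group, so the data give no grounds for a strong shift. Compound 4 is therefore expected to land near compound 2, with a step of a 1.7-fold higher number from compound 2 to compound 4 (0.22 log units; within the scatter) and an estimated value of 60 nM, ranging from 20 nM to 200 nM.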

Compound 4, inhibition constant: 2200 nM
Compound 4: the middle estimate sits 37-fold (1.56 log units) below what was measured; measured number above the stated range.
By their numbers in this assay, from the lowest: compound 3; then compounds 2 and 1 (each within the scatter of the next); then compound 4.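

In this assay the exchange of 4-chloro-2-hydroxyphenyl for 3-ethoxyphenyl on the saturated chain carbon gives a 61-fold higher number from compound 2 to compound 4 (1.79 log units; beyond the scatter) and so shows that this position is far from indifferent to what its aromatic ring carries. The earlier compounds shown here offered no single-place step and gave no sign of so large a change. No measurement at hand accounts for the size of this step.

The chlorine, the hydroxyl and the ethoxy group all change together in this one step, and the compounds shown do not separate their contributions. From the compounds shown here alone, whether an unsubstituted phenyl or a 3-methoxyphenyl group at this place would stay close to compound 2 or fall close to compound 4 remains open.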